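The source may report more compounds than this note shows. Statements on the series, on what has been measured and on what is new or still open speak of the compounds shown alone.

Measured so far in a functional assay on A2780 cells (Homo sapiens) for cytotoxicity, read by MTT assay, with a stated time of 24 h; a lower number here means a stronger inhibitor, a higher number a weaker inhibitor:
- compound 1 `CCCCC[C@H](C[C@@H](O)C[C@@H]1CC=CC(=O)O1)OC`: 54500 nM
- compound 2 `CCCCC[C@H](CCC[C@@H]1CC=CC(=O)O1)OC`: 14400 nM
- compound 3 `CCCCC[C@@H](CCC[C@@H]1CC=CC(=O)O1)OC`: 14900 nM

Compound 1 gives the highest number of the three in this assay; its nearest neighbour is compound 3 and its furthest is compound 2, both beyond the scatter. Within the measured set, the removal of the hydroxy gave a 3.8-fold lower number from compound 1 to compound 2 (0.58 log units; beyond the scatter), while the change of a single centre gave a 1.0-fold higher number from compound 2 to compound 3 (0.01 log units; within the scatter), which rests on (the fact that compounds 2 and 3 differ only in the configuration as drawn).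

The next compound, compound 4 `CCCCC[C@@H](C[C@H](O)C[C@H]1CC=CC(=O)O1)OC`, is related to compound 1 as follows: the two compounds have the same atoms and bonds and differ only in configuration as drawn: 3 of 3 stereo elements differ (all stereocentres are inverted: mirror images); a stereocentre at a saturated chain carbon is drawn R in compound 1 and S in compound 4; a stereocentre at a saturated chain carbon is drawn R in compound 1 and S in compound 4; a stereocentre at a saturated ring carbon is drawn S in compound 1 and R in compound 4. Going by the values given here, no measured pair covers a full mirror image; the only stereochemical comparison available, from compound 2 to compound 3, stayed within the scatter. On that basis no step beyond the scatter is expected in this assay from compound 1 to compound 4, though a full inversion of all three centres is a larger change than the one measured, so the range is kept wide. For compound 4 the estimate is 50000 nM, between 15000 nM and 160000 nM, which would mean a 1.1-fold lower number from compound 1 to compound 4 (0.04 log units; within the scatter).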

Compound 4, half-maximal inhibitory concentration: 53700 nM
For compound 4 the middle estimate is 1.1-fold (0.03 log units) below the measured one; low and high end bracket the measured number.
By their numbers in this assay, from the lowest: compounds 2 and 3 (each within the scatter of the next); then compounds 4 and 1 (each within the scatter of the next).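

In this assay, inverting all three stereocentres, including the one at a saturated ring carbon, gives a 1.0-fold lower number from compound 1 to compound 4 (0.01 log units; within the scatter). Until now, configuration had been tested at a single saturated chain carbon in a pair without the hydroxy; the result extends the lack of a readable change to the hydroxy-bearing pair and to the ring stereocentre: the fact that compounds 1 and 4 differ only in the configuration as drawn. Going by these compounds alone, the only step beyond the scatter remains the replacement of hydroxy by hydrogen, with a 3.8-fold lower number from compound 1 to compound 2 (0.58 log units; beyond the scatter).

A mirror-image pair does not separate the individual centres, so opposing contributions from single stereocentres remain possible, and partial inversions of the hydroxy-bearing compounds are not among those shown. Also open, as far as these compounds go, is how the number would respond to an amine or a carboxylic acid in place of the hydroxy, or to a longer chain.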